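Piperidinyl substitution in a series at the assay limit

The source may report more compounds than this note shows. Statements on the series, on what has been measured and on what is new or still open speak of the compounds shown alone.

Compound 1 `O=c1[nH]c(SCc2cc([N+](=O)[O-])cc([N+](=O)[O-])c2)nc2ccccc12`: > 64000 nM
Compound 2 `O=c1[nH]c(SCc2cc([N+](=O)[O-])cc([N+](=O)[O-])c2)nc2cccc(Cl)c12`: > 64000 nM
Compound 3 `O=c1[nH]c(SCc2cc([N+](=O)[O-])cc([N+](=O)[O-])c2)nc2cc(Cl)ccc12`: > 64000 nM

In an ADME assay on MRC5 cells (Homo sapiens) for cytotoxicity, read by neutral red uptake (on this read-out lower numbers stand for higher toxicity in this test and higher numbers for lower toxicity in this test), compound 1 gives > 64000 nM, which is a limit and not a number. Among the compounds with values here, the series so far offers only this reading: the limit of > 64000 nM in this assay, at which 3 of the 3 values shown sit. Compound 4 `O=c1[nH]c(SCc2cc([N+](=O)[O-])cc([N+](=O)[O-])c2)nc2ccc(N3CCCCC3)cc12` is still unmeasured. Its difference from compound 1 is piperidin-1-yl in place of hydrogen on an aromatic carbon. The nearest measured changes put chloro in place of hydrogen on an aromatic carbon: a step that the two limits leave unreadable from compound 1 to compound 2 and a step that the two limits leave unreadable from compound 1 to compound 3. Neither has a readable size, so the estimate is weakly founded, and any departure is expected toward lower numbers in this assay. The expected step is a number no higher from compound 1 to compound 4 (the limit leaves the size open). For compound 4 the estimate is 64000 nM, with an expected range of 20000 nM to 64000 nM.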

Compound 4, half-maximal cytotoxic concentration: > 64000 nM
Compound 4 ended at the assay's limit; the forecaster's own chance of this, stated with the estimate: 65%; the middle value lies on the limit itself.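

Within the data shown here, compound 1 and compound 4 both stand at a limit, so no step between them can be read. The compounds shown leave open whether any substitution on the shared core shifts the read-out at all: the limit of > 64000 nM in this assay, at which 4 of the 4 values shown sit.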